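The source may report more compounds than this note shows. Statements on the series, on what has been measured and on what is new or still open speak of the compounds shown alone.

Measured so far in an in vitro functional assay on HEK285-7 cells for antagonist activity at prostaglandin D2 receptor 2 (Homo sapiens), read by BRET and beta-arrestin recruitment; on this read-out lower numbers stand for smaller maximal responses and higher numbers for larger maximal responses:
compound 1 `Nc1cc(-c2nc(C(c3ccc(F)cc3)c3ccc(F)cc3)sc2CC(=O)O)cc(F)n1` – 30%
compound 2 `O=C(O)Cc1sc(C(c2ccc(F)cc2)c2ccc(F)cc2)nc1-c1ccccc1` – 80%

Within the data shown here, compound 2 stands highest of the two numbers; its nearest neighbour is compound 1, and the one step that separates them, a number 50 percentage points higher from compound 1 to compound 2 (beyond the scatter), lies beyond the scatter. That step exchanged 2-amino-6-fluoropyridin-4-yl for phenyl on an aromatic carbon of the shared core.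

Compound 3 `O=C(O)Cc1sc(C(c2ccc(F)cc2)c2ccc(F)cc2)nc1-c1ccnc(O)c1` is not yet measured. It differs from compound 2 in one place: 2-hydroxypyridin-4-yl in place of phenyl on an aromatic carbon.

Among the measured compounds shown here, the only measured step that bears on this change is a number 50 percentage points higher from compound 1 to compound 2 (beyond the scatter). The change to compound 3 runs in the opposite sense, from phenyl back to a six-membered aromatic ring with one hetero atom, though the ring now carries a hydroxy group rather than amino and fluoro. The expectation is therefore a step downward in this assay, beyond the scatter, but its size is uncertain, as compound 1 and compound 3 do not carry the same substituents on that ring.

For compound 3 the expected value is 45%, with a range of 20% to 75%. For compound 3 this corresponds to an expected step of a number 35 percentage points lower from compound 2 to compound 3 (beyond the scatter).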

Compound 3, largest response reached (reported as efficacy), in percent of the reference or control that the assay uses: 60%
Beside the measured number, compound 3's estimate is 15 percentage points below it, and the stated range covers the measured number.
By their numbers in this assay, from the lowest: compound 1; then compound 3; then compound 2.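

In this assay, a second ring with a hetero atom at this aromatic carbon of the five-membered aromatic ring again falls short of phenyl, with a number 20 percentage points lower from compound 2 to compound 3 (beyond the scatter) as the step, so the drop seen with compound 1 is no longer a single case. The two rings with a hetero atom also separate from each other, with a number 30 percentage points higher from compound 1 to compound 3 (beyond the scatter) as the step, which shows that the read-out at this position depends on more than the presence of the ring nitrogen: 2-hydroxypyridin-4-yl and 2-amino-6-fluoropyridin-4-yl give clearly different maximal responses. No measurement at hand explains either difference.

The amino and fluoro groups occur only together in compound 1, so the share of each cannot be read, and neither can the contribution of the ring nitrogen apart from the hydroxy group in compound 3. Open comparisons are a plain pyridin-4-yl, a 2-aminopyridin-4-yl, a 2-fluoropyridin-4-yl and a 2-methoxypyridin-4-yl at this same aromatic carbon, each set against phenyl on the shared core.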